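Chain length at the shared core: compound 2 to compound 3

This account rests on a few compounds, and the source may have more. Where it says the series, first, only, none or still open, it means among the compounds named here.

Of the compounds shown here, two carry numbers so far. In a functional assay (aorta) with Oryctolagus cuniculus as the target (a higher number here means a weaker inhibitor, a lower number a stronger inhibitor), compound 1 `OCc1ccc(-c2nn(Cc3ccc(Cl)s3)c3ccccc23)o1` gives 7200 nM. Compound 2 `CC(C)c1cnc(-c2nn(Cc3ccccc3F)c3ncccc23)nc1N` gives 207000 nM in this assay, the highest of the two numbers, and its gap to compound 1 lies well beyond the scatter, so compound 2 is the weaker of the pair. Compound 3 `CCCCCCc1cnc(-c2nn(Cc3ccccc3F)c3ncccc23)nc1N` is not yet measured; it differs from compound 2 by hexyl in place of isopropyl on an aromatic carbon. Within the data shown here, no measured pair shows what such a change does, so the direction of the step is open. The expected step of a 1.4-fold lower number from compound 2 to compound 3 (0.14 log units; within the scatter) is none beyond the scatter, with either direction left possible. For compound 3 the estimate in this assay is 150000 nM, with a range from 40000 nM to 600000 nM, the width reflecting the absence of any guiding pair.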

Compound 3, half-maximal inhibitory concentration: 1040000 nM
The estimate for compound 3 lay 6.9-fold (0.84 log units) below the measured number; measured number above the stated range.
By their numbers in this assay, from the lowest: compound 1; then compound 2; then compound 3.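

This position, an aromatic carbon ortho to an amino group on the six-membered aromatic ring with 2 nitrogen, now has its first measured pair. In this assay, hexyl in place of isopropyl gives a weaker inhibitor (a 5.0-fold higher number from compound 2 to compound 3 (0.70 log units; beyond the scatter)), so here the change in the alkyl group has a readable effect, beyond the scatter, and lengthening it brings no gain. Nothing measured on these compounds accounts for the step.

One pair cannot separate chain length from the loss of branching, and a straight propyl chain at this position would bear on that question. Also open, on these data alone, is whether methyl, ethyl or a chain ending in an amine or a carboxylic acid would give a lower number than isopropyl in this assay.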